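Coumarin amides: a trifluoromethyl step from compound 2 to compound 3

A few compounds are considered here, and "the series" means these few. Any claim that something is new, unique, unknown or untested is made for them only; others in the source may bear on it.

Compound 1 `NCCNC(=O)c1cc2ccccc2oc1=O`: 7680 nM
Compound 2 `O=C(Nc1ccccc1)c1cc2ccccc2oc1=O`: 760 nM

Both compounds share one core and differ only at the amide nitrogen. In an in vitro assay on BTI-TN-5B1-4 cells for inhibition of Amine oxidase [flavin-containing] B (Homo sapiens), read by fluorescence (on this read-out lower numbers stand for stronger inhibition and higher numbers for weaker inhibition), compound 1 gives 7680 nM, and compound 2 gives 760 nM, the lowest of the two numbers shown. Among the measured compounds shown here, the single step measured is a 10-fold lower number from compound 1 to compound 2 (1.00 log units; beyond the scatter).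

For the measured compounds named here, compound 3 `O=C(Nc1cccc(C(F)(F)F)c1)c1cc2ccccc2oc1=O` carries trifluoromethyl in place of hydrogen on an aromatic carbon, a change no measured step addresses, since the only step concerns the amide substituent itself. The expectation therefore rests on compound 2 alone and allows at most a step near the scatter, with the direction uncertain, so the estimated step is a 1.5-fold lower number from compound 2 to compound 3 (0.18 log units; within the scatter). Compound 3 is estimated at 500 nM, within 150 nM to 2500 nM.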

Compound 3, half-maximal inhibitory concentration: 250 nM
Compound 3: the middle estimate sits 2.0-fold (0.30 log units) above what was measured, within the range that was stated.
By their numbers in this assay, from the lowest: compound 3; then compound 2; then compound 1.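

In this assay, trifluoromethyl in place of hydrogen on an aromatic carbon, meta to a large group, gives a 3.0-fold lower number from compound 2 to compound 3 (0.48 log units; beyond the scatter). The earlier step replaced the whole amide substituent, whereas this one shows that the phenyl ring itself can be substituted and that the number falls further at this position. Nothing available explains this step. From the compounds shown here alone, whether the step belongs to trifluoromethyl specifically remains open, since a chlorine atom, a methoxy group or a nitrile could behave differently here. Going by these compounds, how the same group would behave on other carbons of the ring also remains open.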